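Shortening the Chain: From Compound 2 to Compound 3

This account rests on a few compounds, and the source may have more. Where it says the series, first, only, none or still open, it means among the compounds named here.

Compound 2 `CCC/N=C(/NC#N)NCCCn1nc(C)ccc1=O` holds the lowest of the two numbers in a functional assay on the whole organism with Rattus norvegicus as the target, at a dose of 100 mg/kg (on this read-out lower numbers stand for less inhibition and higher numbers for more inhibition at the one dose given (going by the name of the read-out)), with 17.5%, while compound 1 `CC/N=C(/NC#N)NCCCn1nc(C)ccc1=O` gives 34.5%. Compound 3 `C/N=C(/NC#N)NCCCn1nc(C)ccc1=O` differs from compound 2 by hydrogen in place of ethyl on a saturated chain carbon bound to a double-bonded nitrogen. Going by the values given here, the one step that bears on this change is a number 17 percentage points lower from compound 1 to compound 2 (beyond the scatter), where a longer chain went with lower inhibition. The move toward a shorter chain is therefore expected to raise inhibition, a step of a number 27.5 percentage points higher from compound 2 to compound 3 (beyond the scatter). Compound 3 is expected to give about 45%, within a range from 25% to 65%.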

Compound 3, a percentage reported as inhibition, in the whole organism at one dose (the size of the read-out at that dose, not a potency): 6.8%
The estimate for compound 3 lay 38.2 percentage points above the measured number; the measured number lies below the stated range.
By their numbers in this assay, from the lowest: compound 3; then compound 2; then compound 1.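

Hydrogen on this saturated chain carbon bound to a double-bonded nitrogen did not restore the number in this assay but gave a number 10.7 percentage points lower from compound 2 to compound 3 (beyond the scatter) and, against the methyl-bearing chain, a number 27.7 percentage points lower from compound 1 to compound 3 (beyond the scatter). The number therefore does not follow chain length in one direction, as compound 1 stands above both the shorter and the longer chain. Nothing shown gives a reason for this turn.

As far as these compounds go, whether a butyl or isopropyl group at this place would lower the number further stays open. So does whether this order holds at other doses.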